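A few compounds are considered here, and "the series" means these few. Any claim that something is new, unique, unknown or untested is made for them only; others in the source may bear on it.

Measured compounds:
compound 1 `COc1cc(Oc2ccccc2NC(C)=C2C(=O)CC(c3ccccc3)CC2=O)ccc1N`, 29 nM
compound 2 `COc1cccc(Oc2ccccc2NC(C)=C2C(=O)CC(c3ccccc3)CC2=O)c1`, 59 nM

In a functional assay on HMEC-1 cells (Homo sapiens) for antiproliferative activity, read by cell counting, with a stated time of 4 days (on this read-out lower numbers stand for stronger inhibition and higher numbers for weaker inhibition), compound 2 gives the highest of the two numbers shown; the only neighbour is compound 1, and the step of a 2.0-fold higher number from compound 1 to compound 2 (0.31 log units; beyond the scatter) lies beyond the scatter. Compound 3 `CC(=O)c1ccc(Oc2ccccc2NC(C)=C2C(=O)CC(c3ccccc3)CC2=O)cc1` has not been measured. It differs from compound 2 in one place: 4-acetylphenyl in place of 3-methoxyphenyl on an oxygen on an aromatic ring. Among the measured compounds shown here, the single measured step, the loss of an amino group between compound 1 and compound 2, concerns a different substituent of the group that leaves here and does not address an acetyl group taking the place of a methoxy group, so no measured step bears directly on this change. With nothing in the data to point either way, the expected step of a 1.0-fold higher number from compound 2 to compound 3 (0.01 log units; within the scatter) in this assay is none beyond the scatter, with a range wide enough to admit a modest move in either direction. For compound 3 the estimate in this assay is therefore 60 nM, between 25 nM and 150 nM.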

Compound 3, half-maximal inhibitory concentration: 180 nM
Estimate against measurement, compound 3: 3.0-fold (0.48 log units) below; measured number outside the range, above it.
By their numbers in this assay, from the lowest: compound 1; then compound 2; then compound 3.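

In this assay the group on this oxygen proves sensitive to more than the amino group seen earlier: 4-acetylphenyl in place of 3-methoxyphenyl gives a 3.1-fold higher number from compound 2 to compound 3 (0.48 log units; beyond the scatter) and so moves the number beyond the scatter, where the earlier compounds had shown only a change within a single methoxy-bearing ring. Measured against the 4-amino-3-methoxyphenyl group, the same replacement gives a 6.2-fold higher number from compound 1 to compound 3 (0.79 log units; beyond the scatter) and places 4-acetylphenyl as the weakest of the three groups on this oxygen, with its steps to both others beyond the scatter. Nothing in the information available explains why this change raises the number.

The compounds shown leave open whether the acetyl group itself or its place on the ring accounts for the step, since the change alters both at once and neither 3-acetylphenyl nor 4-methoxyphenyl stands among them. They also leave open how a carboxylic acid or an amide carried on this ring, or a simple unsubstituted phenyl group on this oxygen, would read in this assay.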